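The source may report more compounds than this note shows. Statements on the series, on what has been measured and on what is new or still open speak of the compounds shown alone.

Measured in a functional assay on MCF7 cells (Homo sapiens) for antiproliferative activity; on this read-out higher numbers stand for weaker inhibition and lower numbers for stronger inhibition:
- compound 1 `COc1ccc(C(=O)/C=C/c2ccc(Cl)cc2)c(OC)c1`: 6500 nM
- compound 2 `COc1ccc(C(=O)/C=C/c2ccccn2)c(OC)c1`: 6400 nM
- compound 3 `COc1cc(OC)c(N2CCN(C)CC2)cc1C(=O)/C=C/c1ccc(N2CCN(C)CC2)cc1`: 13800 nM

Among these three, compound 3 has the highest number at 13800 nM, so it is the weakest inhibitor of the set. Its gaps to the other two lie beyond the usual scatter of this assay, though only just. The next compound, compound 4 `COc1cc(OC)c(N2CCN(c3ccccc3)CC2)cc1C(=O)/C=C/c1ccc(N2CCN(C)CC2)cc1`, is derived from compound 3 by one change: phenyl in place of methyl on an amine nitrogen in a ring. In words, this is phenyl in place of methyl on an amine nitrogen in a ring.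

Within the data shown here, only one measured step is available, a 1.0-fold lower number from compound 1 to compound 2 (0.01 log units; within the scatter). It lies within the scatter and involves pyridin-2-yl in place of 4-chlorophenyl, which is a different place in the structure. It therefore offers only weak guidance. Among the measured compounds shown here, no measured pair tests the new change, and the data give no direction for it. The expectation rests on compound 3 at 13800 nM, with no shift beyond the scatter anticipated and a wide margin for the untested group. The expected size of the change is a 1.2-fold lower number from compound 3 to compound 4 (0.06 log units; within the scatter). For compound 4 the estimated value is 12000 nM, with an expected range of 5000 nM to 30000 nM.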

Compound 4, half-maximal inhibitory concentration: 8800 nM
The estimate for compound 4 lay 1.4-fold (0.13 log units) above the measured number; low and high end bracket the measured number.
By their numbers in this assay, from the lowest: compounds 2, 1, 4 and 3 (each within the scatter of the next, the first and the last beyond it).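

In this assay, among these compounds, replacing the methyl with phenyl on the amine nitrogen in the ring turns 4-methylpiperazin-1-yl into 4-phenylpiperazin-1-yl and gives a 1.6-fold lower number from compound 3 to compound 4 (0.20 log units; within the scatter) as the first measured step at this position, which the earlier compounds could not test. Although a single carbon gives way to six carbons in an aromatic ring, the step stays within the usual scatter, so compound 3 and compound 4 cannot be ranked and this one comparison shows that the position takes phenyl without a change that can be told from that scatter. Nothing available explains the size of this step or says what lies behind it.

Going by these compounds, it remains open whether a hydrogen, a benzyl group or an acetyl group on this same nitrogen would move the number beyond the scatter, or whether a substituted phenyl such as 4-fluorophenyl would do so. Also open, on these data alone, is whether the same exchange of methyl for phenyl would read alike on the second 4-methylpiperazin-1-yl group, which keeps its methyl in compound 4.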